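Inverting One Stereocentre at the Cytotoxicity Limit

The source may report more compounds than this note shows. Statements on the series, on what has been measured and on what is new or still open speak of the compounds shown alone.

Of the compounds shown here, three sharing one core have been tested in an ADME assay on HEK293 cells (Homo sapiens) for cytotoxicity, with a stated time of 6 h; on this read-out lower numbers stand for higher toxicity in this test and higher numbers for lower toxicity in this test. Compound 1 (`CCCCNc1nc(N)nc2cccc(C(=O)NC)c12`) reads > 25000 nM, which is a limit of the assay. Compound 2 (`CCCCNc1nc(N)nc2cccc(C(=O)N(C)Cc3ccccc3)c12`) reads > 25000 nM, again a limit. Compound 3 (`CCCCNc1nc(N)nc2cccc(C(=O)N[C@H](C)c3ccccc3)c12`) reads > 25000 nM, also only a limit. All readings thus sit at one edge: the limit of > 25000 nM in this assay, at which 3 of the 3 values shown sit. Compound 4 (`CCCCNc1nc(N)nc2cccc(C(=O)N[C@@H](C)c3ccccc3)c12`) differs from compound 3 in one respect: the two compounds have the same atoms and bonds and differ only in configuration as drawn: 1 of 1 stereo elements differ; a stereocentre at a saturated chain carbon is drawn R in compound 3 and S in compound 4. Within the data shown here, three measured steps bear on it: a step that the two limits leave unreadable from compound 1 to compound 2, a step that the two limits leave unreadable from compound 1 to compound 3 and a step that the two limits leave unreadable from compound 2 to compound 3. None gives a size to carry over, so no step beyond the scatter is expected in this assay. The estimated step is a step that the limit leaves unreadable from compound 3 to compound 4. Compound 4 is expected at 30000 nM, with an estimated range from 15000 nM to 60000 nM.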

Compound 4, half-maximal cytotoxic concentration: > 25000 nM
Compound 4 gave a limit, no number; the forecaster's own chance of this, stated with the estimate: 85%; the middle value is on the limit's open side.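

Compound 4, like compounds 1, 2 and 3, gives only a limit in this assay, so no step among them can be read: the limit of > 25000 nM in this assay, at which 4 of the 4 values shown sit.

The compounds shown leave open whether compound 3 and compound 4 differ in this assay at all, and at what concentration any of the four becomes cytotoxic.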